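Bromo replacing trifluoromethyl on the pendant phenyl ring

The source may hold more compounds than are shown below. What is called first, only, known or untested is meant among the compounds shown, and "the series" means these compounds.

compound 1, `COc1ccc(-c2cc(C(=O)Nc3ccc(Oc4ccnc5[nH]ccc45)cc3)ncn2)cc1`: in a functional assay on MCF7 cells (Homo sapiens) for cytotoxicity, read by MTT assay, with a stated time of 72 h (a lower number here means a stronger inhibitor, a higher number a weaker inhibitor), compound 1 gives 4450 nM
compound 2, `O=C(Nc1ccc(Oc2ccnc3[nH]ccc23)cc1)c1cc(-c2ccc(F)cc2)ncn1`: compound 2 gives 15900 nM
compound 3, `O=C(Nc1ccc(Oc2ccnc3[nH]ccc23)cc1)c1cc(-c2ccc(C(F)(F)F)cc2)ncn1`: compound 3 gives 6240 nM

Compound 3 holds the second highest of the three numbers in this assay. Its nearest neighbour is compound 1, and the step of a 1.4-fold higher number from compound 1 to compound 3 (0.15 log units; within the scatter) stays within the scatter, so the two are not separated. The step of a 2.5-fold lower number from compound 2 to compound 3 (0.41 log units; beyond the scatter) is beyond the scatter and is the one clear gap in the set.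

Compound 4, `O=C(Nc1ccc(Oc2ccnc3[nH]ccc23)cc1)c1cc(-c2ccc(Br)cc2)ncn1`, differs from compound 3 by bromo in place of trifluoromethyl on an aromatic carbon. Within the data shown here, no bromo analogue has been measured, so the bearing steps are those at the same position: a 2.5-fold lower number from compound 2 to compound 3 (0.41 log units; beyond the scatter) and a 3.6-fold higher number from compound 1 to compound 2 (0.55 log units; beyond the scatter), both modest, showing the fluoro compound 2 with the highest number of the three. Bromo sits between those precedents with no direct anchor; the expected step of a 1.3-fold higher number from compound 3 to compound 4 (0.11 log units; within the scatter) is therefore small, likely within the scatter, with a slight lean toward a higher number.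

Compound 4 is estimated at 8000 nM, with a range of 3000 nM to 20000 nM.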

Compound 4, half-maximal inhibitory concentration: 3840 nM
Beside the measured number, compound 4's estimate is 2.1-fold (0.32 log units) above it; the measured number falls inside the stated range.
By their numbers in this assay, from the lowest: compounds 4, 1 and 3 (each within the scatter of the next); then compound 2.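

In this assay, bromo at this place on the pendant phenyl ring is not separated from trifluoromethyl (a 1.6-fold lower number from compound 3 to compound 4 (0.21 log units; within the scatter)) or from methoxy (a 1.2-fold lower number from compound 1 to compound 4 (0.06 log units; within the scatter)), so compound 1, compound 3 and compound 4 now read as one group. Fluoro alone stands apart (a 4.1-fold lower number from compound 2 to compound 4 (0.62 log units; beyond the scatter)), the largest step in the set, and compound 2 is the only compound whose steps to all the others lie beyond the scatter. Nothing available explains why fluoro differs from the other three groups.

Open, going by these compounds, is how an amine or a carboxylic acid at this place would read in this assay, and whether chloro would fall with bromo or with fluoro. Also open, on these data alone, is whether the gap around compound 2 holds in other cell lines.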